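The source may hold more compounds than are shown below. What is called first, only, known or untested is meant among the compounds shown, and "the series" means these compounds.

Three compounds share one core and differ only in the side chain on an oxygen on an aromatic ring. Compound 1 `C=C(C)C(=O)NCCOc1ccc(Oc2c(-c3ccc(F)cc3)sc3cc(O)ccc23)cc1` reaches only the limit of a functional assay on MCF7 cells (Homo sapiens) for antiproliferative activity, read by CCK-8 assay, with a stated time of 48 h; on this read-out lower numbers stand for stronger inhibition and higher numbers for weaker inhibition: its value there, > 25000 nM, is a limit and not a number (the limit of > 25000 nM in this assay, at which 1 of the 3 values shown sits). Compound 2 `C/C=C/C(=O)NCCOc1ccc(Oc2c(-c3ccc(F)cc3)sc3cc(O)ccc23)cc1` gives 21700 nM in this assay. Compound 3 `C=CC(=O)N1CC(Oc2ccc(Oc3c(-c4ccc(F)cc4)sc4cc(O)ccc34)cc2)C1` gives 23500 nM in this assay, the highest of the two numbers, although the step of a 1.1-fold higher number from compound 2 to compound 3 (0.03 log units; within the scatter) and the step of an at least 1.0-fold lower number from compound 1 to compound 3 (0.02 log units; that floor lies within the scatter) both lie within the scatter. Compound 4 `O=C(/C=C/CNCCOc1ccc(Oc2c(-c3ccc(F)cc3)sc3cc(O)ccc23)cc1)N1CCC1` is the compound still to be measured; it differs from compound 3 by 2-((3-((azetidin-1-yl)carbonyl)prop-2-en-1-yl)amino)ethyl in place of 1-(vinylcarbonyl)azetidin-3-yl on an oxygen on an aromatic ring. Because the steps of a 1.1-fold higher number from compound 2 to compound 3 (0.03 log units; within the scatter) and an at least 1.0-fold lower number from compound 1 to compound 3 (0.02 log units; that floor lies within the scatter) stayed within the scatter while the side chain on that oxygen was rebuilt, a further rebuilding there is expected to leave the read-out about where it is, and the step of a 1.2-fold lower number from compound 3 to compound 4 (0.07 log units; within the scatter) is expected to stay within the scatter. Compound 4 is therefore estimated at 20000 nM in this assay, with a range from 7000 nM to 50000 nM.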

Compound 4, half-maximal inhibitory concentration: 7340 nM
The estimate for compound 4 lay 2.7-fold (0.44 log units) above the measured number, within the range that was stated.
By their numbers in this assay, from the lowest: compound 4; then compounds 2 and 3 (each within the scatter of the next). At a limit, above all of these: compound 1.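

Rebuilding the side chain on this oxygen had so far moved nothing beyond the scatter, but in this assay the new side chain, 2-((3-((azetidin-1-yl)carbonyl)prop-2-en-1-yl)amino)ethyl, gives a 3.2-fold lower number from compound 3 to compound 4 (0.51 log units; beyond the scatter) and, on the amine nitrogen, a 3.0-fold lower number from compound 2 to compound 4 (0.47 log units; beyond the scatter). The position therefore does respond to a change of side chain, and the comparison with compound 1 points the same way, with an at least 3.4-fold lower number from compound 1 to compound 4 (0.53 log units; beyond the scatter). That step is only a floor, as compound 1 has a limit and not a number: the limit of > 25000 nM in this assay, at which 1 of the 4 values shown sits.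

The compounds shown do not separate the azetidin-1-yl carbonyl from the change on the amine nitrogen, as both arrive in the same step. An open-chain dimethylamide in place of the azetidine amide, or a longer chain on the amine nitrogen, would be needed to tell these parts apart.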